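Diacylhydrazine series: para-alkyl extension on the benzoyl ring

The source may hold more compounds than are shown below. What is called first, only, known or untested is meant among the compounds shown, and "the series" means these compounds.

Measured so far: compound 1 `Cc1cccc(C(=O)NN(C(=O)c2ccccc2Cl)C(C)(C)C)c1` gives 603 nM in an assay on cells for agonist activity at ecdysone receptor (Bombyx mori), read by a luciferase reporter, with a stated time of 24 h; a lower number here means that less compound is needed, a higher number that more compound is needed for the effect; compound 2 `Cc1ccc(C(=O)NN(C(=O)c2ccccc2Cl)C(C)(C)C)cc1` gives 18.6 nM.

Within the data shown here, compound 2 holds the lowest number of the two, and the only step available, a 32-fold lower number from compound 1 to compound 2 (1.51 log units; beyond the scatter), is large and beyond the scatter. Compound 3 `CCc1ccc(C(=O)NN(C(=O)c2ccccc2Cl)C(C)(C)C)cc1` is the next case, differing from compound 2 by methyl in place of hydrogen on a saturated chain carbon bound to an aromatic carbon.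

Among the measured compounds shown here, no measured step speaks to this change directly: the one step available concerns where the methyl sits on the ring, not how long the chain is, so the data give no direction for lengthening the 4-methyl to 4-ethyl. The expectation is therefore a step within the scatter, with no reason for a change beyond it. For compound 3 the estimate is 13 nM (range 4 nM to 45 nM), which would mean an expected step of a 1.4-fold lower number from compound 2 to compound 3 (0.16 log units; within the scatter).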

Compound 3, half-maximal effective concentration: 5.75 nM
The estimate for compound 3 lay 2.3-fold (0.35 log units) above the measured number; the range from low to high includes it.
By their numbers in this assay, from the lowest: compound 3; then compound 2; then compound 1.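

In this assay, the change from 4-methylphenyl to 4-ethylphenyl gives a 3.2-fold lower number from compound 2 to compound 3 (0.51 log units; beyond the scatter) and so shows that the chain itself matters, whereas the earlier step spoke only to where the methyl sits on the ring. Among these compounds, compound 3 now holds the lowest number of the three, and a 100-fold lower number from compound 1 to compound 3 (2.02 log units; beyond the scatter) gives the full span of the series so far, with most of it already present in the step to compound 2. Nothing at hand accounts for either step.

From the compounds shown here alone, whether the number keeps falling with a propyl group or a longer chain in place of the ethyl remains open. Also open, going by these compounds, is whether a methoxy group or an amine at that place would fit as well, and whether the same methyl addition would lower the number on 3-methylphenyl.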